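From chloro to trifluoromethyl in a three-compound series

The compounds below may be only part of what the source reports. "The series", "measured", "known", "first", "only" and "open" are said of these compounds alone.

In a physicochemical assay for pharmacokinetics, at pH 6 (a higher number here means that the compound lasts longer, a lower number that the compound disappears faster), compound 1 (`O=C(Sc1cccnc1C(=O)O)c1ccccc1`) gives 21.1 h. Chloro in place of hydrogen on an aromatic carbon gives compound 2 (`O=C(Sc1cccnc1C(=O)O)c1cccc(Cl)c1`) at 4.7 h and compound 3 (`O=C(Sc1cccnc1C(=O)O)c1ccc(Cl)cc1`) at 7.9 h. Both steps are modest and beyond the scatter: a 4.5-fold lower number from compound 1 to compound 2 (0.65 log units; beyond the scatter) and a 2.7-fold lower number from compound 1 to compound 3 (0.43 log units; beyond the scatter). Compound 3 therefore stands clearly under compound 1, while its value lies within the scatter of that of compound 2, so this assay does not separate these two chloro compounds.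

Compound 4 (`O=C(Sc1cccnc1C(=O)O)c1ccc(C(F)(F)F)cc1`) has not yet been measured. It carries trifluoromethyl in place of chloro on an aromatic carbon. For the measured compounds named here, no measured step makes this exchange directly, so the evidence is indirect. The closest guide is a 2.7-fold lower number from compound 1 to compound 3 (0.43 log units; beyond the scatter), the step that brought in the chloro now leaving, and a 4.5-fold lower number from compound 1 to compound 2 (0.65 log units; beyond the scatter) points the same way. Both show a chloro substituent lowering the number, and the same direction is tentatively expected for its larger replacement. The estimated change is small, a 1.4-fold lower number from compound 3 to compound 4 (0.16 log units; within the scatter), and it is expected to stay within the scatter. For compound 4 the expected half-life is 5.5 h, with an estimated range of 2.8 h to 10.5 h.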

Compound 4, half-life: 3 h
For compound 4 the middle estimate is 1.8-fold (0.26 log units) above the measured one, within the range that was stated.
By their numbers in this assay, from the lowest: compounds 4, 2 and 3 (each within the scatter of the next, the first and the last beyond it); then compound 1.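

For the compounds shown here, at this place, on an aromatic carbon para to a large group, the earlier compounds showed only that chloro lowers the number relative to hydrogen; compound 4 shows that this assay also separates two substituents from each other, with trifluoromethyl in place of chloro giving a 2.6-fold lower number from compound 3 to compound 4 (0.42 log units; beyond the scatter) and so a modest step that lies beyond the scatter. Going by these compounds alone, measured against the unsubstituted compound, trifluoromethyl in place of hydrogen gives a 7.0-fold lower number from compound 1 to compound 4 (0.85 log units; beyond the scatter) and so extends the downward direction already seen with chloro at this place, with no compound here going against it. Nothing in the available data bears on why the half-life follows this order, so the result stands as an observation only.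

The compounds shown leave open whether an amine, a methoxy group or a carboxylic acid at this same place would also lower the number, or whether the downward direction belongs only to chloro and trifluoromethyl. They also leave open how trifluoromethyl would behave at the place that carries chloro in compound 2.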